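Ethoxymethyl to acetoxymethyl on the shared core

This account rests on a few compounds, and the source may have more. Where it says the series, first, only, none or still open, it means among the compounds named here.

In a functional assay on A549 cells (Homo sapiens) for cytotoxicity, read by sulforhodamine B assay, with a stated time of 3 days (a higher number here means that more compound is needed for the effect, a lower number that less compound is needed), compound 1 `CCOCc1c(C)coc1-c1ccc2c(c1OC)CCCC2(C)C` gives 22.9 uM. Among the compounds with values here, the only other measured compound, compound 2 `Cc1coc(-c2ccc3c(c2O)CCCC3(C)C)c1CO`, gives 24.5 uM. Within the data shown here, these two numbers lie within the usual scatter of each other, so compound 1 stands level with its sole neighbour. Compound 3 `COc1c(-c2occ(C)c2COC(C)=O)ccc2c1CCCC2(C)C` carries acetyl in place of ethyl on an oxygen on a saturated carbon. Among the measured compounds shown here, no measured step covers this change, so no shift beyond the scatter is expected in this assay, and the estimated move is a 1.1-fold lower number from compound 1 to compound 3 (0.06 log units; within the scatter). Compound 3 is estimated at 20 uM, with an expected range of 10 uM to 40 uM.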

Compound 3, concentration for half-maximal effect: 28.7 uM
Estimate against measurement, compound 3: 1.4-fold (0.16 log units) below; measured number inside the range.
By their numbers in this assay, from the lowest: compounds 1, 2 and 3 (each within the scatter of the next).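

In this assay, acetyl in place of ethyl on an oxygen on a saturated carbon gives a 1.3-fold higher number from compound 1 to compound 3 (0.10 log units; within the scatter), the first step read at this position. The entering acetyl adds a double bond outside aromatic rings and a hydrogen-bond acceptor, yet this exchange leaves the number level with that of compound 1. No evidence bears on this result.

From the compounds shown here alone, whether an amine, a carboxylic acid or a longer chain on this oxygen would move the number beyond the scatter remains open.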